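Swapping methoxy for nitro on compound 2

The source may report more compounds than this note shows. Statements on the series, on what has been measured and on what is new or still open speak of the compounds shown alone.

In a functional assay on MDA-MB-468 cells (Homo sapiens) for antiproliferative activity, read by MTT assay, with a stated time of 72 h (on this read-out higher numbers stand for weaker inhibition and lower numbers for stronger inhibition), compound 1 `COc1cc(-c2nccn2-c2cccc(C)c2)cc(OC)c1OC` gives 22600 nM, and compound 2 `COc1cccc(-n2ccnc2-c2cc(OC)c(OC)c(OC)c2)c1` gives 10400 nM, the lower of the two numbers and so the stronger inhibition. Compound 3 `COc1cc(-c2nccn2-c2cccc([N+](=O)[O-])c2)cc(OC)c1OC` has nitro in place of methoxy on an aromatic carbon, (nitro in place of methoxy on an aromatic carbon). Within the data shown here, no measured step involves nitro. Among the measured compounds shown here, the only guide is a 2.2-fold lower number from compound 1 to compound 2 (0.34 log units; beyond the scatter), a modest step with methoxy in place of methyl, so a similarly modest step of uncertain direction is expected in this assay. The expected step is a 1.4-fold higher number from compound 2 to compound 3 (0.16 log units; within the scatter). For compound 3 the estimated value is 15000 nM, with an expected range from 5000 nM to 45000 nM.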

Compound 3, half-maximal inhibitory concentration: 7200 nM
Compound 3: middle estimate off by 2.1-fold (0.32 log units), on the high side; measured number inside the range.
By their numbers in this assay, from the lowest: compounds 3 and 2 (each within the scatter of the next); then compound 1.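

In this assay, the nitro and methoxy groups cannot be told apart at this position, with a 1.4-fold lower number from compound 2 to compound 3 (0.16 log units; within the scatter). Against methyl the change is clearer, with a 3.1-fold lower number from compound 1 to compound 3 (0.50 log units; beyond the scatter), so both methoxy and nitro stand apart from methyl here, even though the two groups differ in heavy atoms and hydrogen-bond acceptors. Nothing measured explains this result.

As far as these compounds go, what stays open is how an amine or a carboxylic acid would behave at this position. From the compounds shown here alone, it is also open whether any group here could bring the number far lower.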